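Replacing Cyano with Fluoro: What to Expect for Compound 4

The compounds below may be only part of what the source reports. "The series", "measured", "known", "first", "only" and "open" are said of these compounds alone.

Measured so far in a functional assay on HepG2 cells (Homo sapiens) for inhibition, read by MTT assay, with a stated time of 24 h; a lower number here means a stronger inhibitor, a higher number a weaker inhibitor
Compound 1 `CC1(C)[C@H]2CC[C@]1(C)N(Cc1cn(-c3cccc(F)c3)nn1)C(=O)C2` gives 80 nM
Compound 2 `CC1(C)[C@H]2CC[C@]1(C)N(Cc1cn(-c3ccccc3Br)nn1)C(=O)C2` gives 150 nM
Compound 3 `CC1(C)[C@H]2CC[C@]1(C)N(Cc1cn(-c3ccccc3C#N)nn1)C(=O)C2` gives 180 nM

Compound 3, at 180 nM, cannot be separated from compound 2. Only compound 1 stands clearly apart from it, and that gap is modest: a 2.3-fold higher number from compound 1 to compound 3 (0.35 log units; beyond the scatter).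

Compound 4 `CC1(C)[C@H]2CC[C@]1(C)N(Cc1cn(-c3ccccc3F)nn1)C(=O)C2` shares the core of compound 3 but carries fluoro in place of cyano on an aromatic carbon, ortho to a large group (fluoro in place of cyano on an aromatic carbon).

Among the measured compounds shown here, no measured compound matches this change directly, so the evidence is indirect. The exchange of bromo for cyano gave a 1.2-fold higher number from compound 2 to compound 3 (0.08 log units; within the scatter), and the other step available is a 1.9-fold higher number from compound 1 to compound 2 (0.27 log units; within the scatter). Compound 1 also carries fluoro and gives 80 nM, which suggests a slight lean towards a lower number in this assay. The expected change is a 1.4-fold lower number from compound 3 to compound 4 (0.14 log units; within the scatter). Compound 4 is estimated at 130 nM, with an expected range of 60 nM to 280 nM.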

Compound 4, half-maximal inhibitory concentration: 60 nM
Estimate against measurement, compound 4: 2.2-fold (0.34 log units) above; low and high end bracket the measured number.
By their numbers in this assay, from the lowest: compounds 4, 1, 2 and 3 (each within the scatter of the next, the first and the last beyond it).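

Putting fluoro in place of cyano at this place, ortho to a large group, gives a real change: a 3.0-fold lower number from compound 3 to compound 4 (0.48 log units; beyond the scatter). Fluoro also stands apart from bromo at the same place, with a 2.5-fold lower number from compound 2 to compound 4 (0.40 log units; beyond the scatter), whereas bromo and cyano could not be separated, so the earlier compounds gave no sign that the group here mattered this much. Moving the fluoro around the phenyl ring, on the other hand, shows no clear change, with a 1.3-fold lower number from compound 1 to compound 4 (0.12 log units; within the scatter), so 2-fluorophenyl and 3-fluorophenyl cannot be told apart in this test, and nothing available explains any of these steps.

Still open, as far as these compounds go, is how a methyl group, a methoxy group or an amine at this same place would compare with fluoro. Also open, from the compounds shown here alone, is whether a second fluoro on the phenyl ring would shift the number further.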